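A few compounds are considered here, and "the series" means these few. Any claim that something is new, unique, unknown or untested is made for them only; others in the source may bear on it.

Values in a functional assay on PC-3 cells (Homo sapiens) for antiproliferative activity, read by MTT assay, with a stated time of 96 h; a lower number here means a stronger inhibitor of growth, a higher number a weaker inhibitor of growth:
Compound 1 `COc1ccc(Cl)c2ccc(Nc3ccccn3)nc12`: 29200 nM.
Compound 2 `COc1ccc(Cl)c2ccc(Nc3cc(Cl)ccn3)nc12`: > 30000 nM, a limit of the assay.
Compound 3 `Oc1ccc(Cl)c2ccc(Nc3ccccn3)nc12`: 1290 nM.

Compound 3 holds the lower of the two actual numbers, the reading for compound 2 being a limit. Compound 4 `Oc1ccc(Cl)c2ccc(Nc3cc(Cl)ccn3)nc12` has chloro in place of hydrogen on an aromatic carbon, opposite the ring nitrogen (chloro in place of hydrogen on an aromatic carbon). The same exchange gave an at least 1.0-fold higher number from compound 1 to compound 2 (0.01 log units; that floor lies within the scatter), which rests on the limit of > 30000 nM in this assay, at which 1 of the 3 values shown sits, and leaves its true size open. The other measured step, a 23-fold lower number from compound 1 to compound 3 (1.35 log units; beyond the scatter), is a different change. A small rise in this assay, within the scatter, is therefore expected: a 1.6-fold higher number from compound 3 to compound 4 (0.19 log units; within the scatter). For compound 4 the estimated value is 2000 nM, with an expected range of 600 nM to 9000 nM.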

Compound 4, concentration for 50% growth inhibition: 25500 nM
Compound 4: middle estimate off by 13-fold (1.11 log units), on the low side; measured number outside the range, above it.
By their numbers in this assay, from the lowest: compound 3; then compounds 4 and 1 (each within the scatter of the next). At a limit, above all of these: compound 2.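

In this assay, chloro in place of hydrogen on an aromatic carbon, opposite the ring nitrogen, is a large change on the core of compound 3: a 20-fold higher number from compound 3 to compound 4 (1.30 log units; beyond the scatter). This gives the first measured size for the change at this position, as the earlier step (an at least 1.0-fold higher number from compound 1 to compound 2 (0.01 log units; that floor lies within the scatter)) gave only a floor: the same change on two cores in this assay, an at least 1.0-fold higher number (0.01 log units; that floor lies within the scatter) from compound 1 to compound 2 and a 20-fold higher number (1.30 log units; beyond the scatter) from compound 3 to compound 4; the limit leaves it open whether they differ. The other new step (an at least 1.1-fold lower number from compound 2 to compound 4 (0.07 log units; that floor lies within the scatter)) is only a floor, as it rests on a limit: the limit of > 30000 nM in this assay, at which 1 of the 4 values shown sits.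

Open, from the compounds shown here alone, is whether fluoro or an amine at this position would stay close to compound 3 at 1290 nM.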